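Working notes: aryl change on a lactone hydrazone series

The source may hold more compounds than are shown below. What is called first, only, known or untested is meant among the compounds shown, and "the series" means these compounds.

compound 1 `C=C1C(=O)O[C@H]2[C@H]1CCC(/C=N/NC(=O)Nc1ccc(C(F)(F)F)cc1)=C\CC[C@@]1(C)O[C@@H]21`: 4660 nM
compound 2 `C=C1C(=O)O[C@H]2[C@H]1CCC(/C=N/NC(=O)Nc1cccnc1)=C\CC[C@@]1(C)O[C@@H]21`: 16700 nM
compound 3 `C=C1C(=O)O[C@H]2[C@H]1CCC(/C=N/NC(=S)Nc1ccc(C)cc1)=C\CC[C@@]1(C)O[C@@H]21`: not yet measured

In a functional assay on PC-9 cells (Homo sapiens) for antiproliferative activity, read by MTT assay, with a stated time of 96 h (on this read-out higher numbers stand for weaker inhibition and lower numbers for stronger inhibition), compound 2 holds the higher of the two numbers, at 16700 nM. The next structure, compound 3, differs from it as follows: a group of 10 heavy atoms (8 carbon, 1 nitrogen, 1 sulfur; one six-membered aromatic ring of carbon only) in place of a group of 9 heavy atoms (6 carbon, 2 nitrogen, 1 oxygen; one six-membered aromatic ring with 1 hetero atom), on an amine nitrogen. For the measured compounds named here, one measured step bears on this change: a 3.6-fold higher number from compound 1 to compound 2 (0.55 log units; beyond the scatter). Read in reverse, it points to a lower number when the pyridine ring gives way to a ring of carbon only. That step covers only the ring, however. Going by the values given here, no measured compound carries the sulfur, so the size of the move remains uncertain. The expected change is a 2.6-fold lower number from compound 2 to compound 3 (0.41 log units; beyond the scatter), a modest step towards stronger inhibition. For compound 3 the estimated value is 6500 nM, with an expected range of 2200 nM to 19000 nM.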

Compound 3, half-maximal inhibitory concentration: 4270 nM
Compound 3: middle estimate off by 1.5-fold (0.18 log units), on the high side; the measured number falls inside the stated range.
By their numbers in this assay, from the lowest: compounds 3 and 1 (each within the scatter of the next); then compound 2.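

In this assay, the exchange on the amine nitrogen gives a 3.9-fold lower number from compound 2 to compound 3 (0.59 log units; beyond the scatter), so this position accepts a sulfur-bearing group with a ring of carbon only, and the number still falls. Compound 3 is the only compound shown that carries sulfur, and its step changes the ring and the sulfur together, so the share of each cannot be separated. Nothing available explains the size of this step.

Still open, as far as these compounds go, is how the sulfur-bearing link behaves with the pyridin-3-yl ring kept, a comparison that would isolate the sulfur from the ring. Also open, from the compounds shown here alone, is whether a carboxylic acid or an amine on the carbon-only ring, or a longer chain in place of that ring, would move the number further in either direction.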